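The compounds below may be only part of what the source reports. "The series", "measured", "known", "first", "only" and "open" are said of these compounds alone.

Measured so far:
compound 1, `Cc1ccc(S(=O)(=O)n2cc(-c3cc(C(F)(F)F)ccn3)c3cc(Br)ccc32)cc1`, gives 32.8% in a functional assay on A549 cells (Homo sapiens) for inhibition, tested at 1 uM; a higher number here means a stronger effect of the compound at the concentration tested, a lower number a weaker effect.
compound 2, `COc1ccc2c(c1)c(-c1cc(C(F)(F)F)cc(-c3cn(S(=O)(=O)c4ccc(C)cc4)c4ccc(OC)cc34)n1)cn2S(=O)(=O)c1ccc(C)cc1`, gives 7.1% in this assay.

Compound 1 stands highest of the two numbers; its nearest neighbour is compound 2, whose value lies lower by a margin beyond the scatter. Going by the values given here, no pair of compounds differing in a single place has been measured, so no step can be quoted from these two alone; their values show only that the smaller compound 1 gives the stronger effect at this concentration.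

The next compound to be measured is compound 3, `COc1ccc2c(c1)c(-c1cc(C(F)(F)F)ccn1)cn2S(=O)(=O)c1ccc(C)cc1`. Relative to compound 1 the change is methoxy in place of bromo on an aromatic carbon. It keeps the remainder of the core of compound 1 intact.

Without a measured step for this kind of exchange, the expected size of the change rests only on the value of compound 1, 32.8%, and on the weaker value of compound 2, which also carries methoxy groups. Compound 3 is therefore expected to come in somewhat lower than compound 1, with the step of a number 10.8 percentage points lower from compound 1 to compound 3 (beyond the scatter) estimated to be modest and perhaps within the scatter. The estimate for compound 3 in this assay is 22%, in the range 5% to 40%.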

Compound 3, a percentage reported as inhibition, at one concentration (the size of the read-out at that concentration, not a potency): 23.2%
The estimate for compound 3 lay 1.2 percentage points below the measured number, and the stated range covers the measured number.
By their numbers in this assay, from the lowest: compound 2; then compounds 3 and 1 (each within the scatter of the next).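

In this assay, going by these compounds alone, compound 1 and compound 3 form the first pair that differs in one place, and the step for methoxy in place of bromo is a number 9.6 percentage points lower from compound 1 to compound 3 (within the scatter). At this aromatic carbon, meta to a fused ring and para to a fused ring, the exchange brings in one more heavy atom and a hydrogen-bond acceptor, yet the two numbers cannot be told apart, so the pair shows no measurable preference between these two groups at this concentration. No measurement available here bears on the reason for this result.

From the compounds shown here alone, what an amine, a carboxylic acid or a longer chain such as butoxy would give at this same aromatic carbon stays open, as does the number for the core with plain hydrogen there. Also open, going by these compounds, is whether the parity of bromo and methoxy would hold at other concentrations, as each number is the size of the read-out at a single concentration and not a potency.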